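A pyridin-4-yl swap with a flat outcome expected

The source may report more compounds than this note shows. Statements on the series, on what has been measured and on what is new or still open speak of the compounds shown alone.

In a functional assay on CHO cells with adenosine receptor A1 (Homo sapiens) as the target, read by cAMP accumulation and immunoassay, with a stated time of 6 min, tested at 0.01 uM (on this read-out lower numbers stand for a stronger effect and higher numbers for a weaker effect at the one concentration tested), compound 1 `Nc1scc(CN2CCN(c3cccc(Cl)c3Cl)CC2)c1C(=O)c1ccc(Cl)cc1` gives 1%. Of the three numbers measured, compound 1 stands second highest; its nearest neighbour is compound 2 `Nc1scc(CN2CCN(c3cc(Cl)cc(Cl)c3)CC2)c1C(=O)c1ccc(Cl)cc1`, which gives -1%, and its furthest is compound 3 `Nc1scc(CN2CCN(c3cccnc3)CC2)c1C(=O)c1ccc(Cl)cc1`, which gives 3.2%. The step of a number 2 percentage points lower from compound 1 to compound 2 (within the scatter) and the step of a number 2.2 percentage points higher from compound 1 to compound 3 (within the scatter) both lie within the scatter, as does a number 4.2 percentage points higher from compound 2 to compound 3 (within the scatter). Compound 4 `Nc1scc(CN2CCN(c3ccncc3)CC2)c1C(=O)c1ccc(Cl)cc1` is not yet measured. It differs from compound 1 as follows: pyridin-4-yl in place of 2,3-dichlorophenyl on an amine nitrogen in a ring. The step that bears most directly on this change is a number 2.2 percentage points higher from compound 1 to compound 3 (within the scatter), where another pyridinyl ring replaced the same 2,3-dichlorophenyl and the number did not move beyond the scatter; the steps to the 3,5-dichlorophenyl compound were equally small. Compound 4 is therefore expected to show no step beyond the scatter, a number 1 percentage points higher from compound 1 to compound 4 (within the scatter). The estimate for compound 4 in this assay is 2%, within a range from -8% to 12%.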

Compound 4, a percentage reported as activity, at one concentration (the size of the read-out at that concentration, not a potency): -4%
Estimate against measurement, compound 4: 6 percentage points above, and the stated range covers the measured number.
By their numbers in this assay, from the lowest: compounds 4, 2, 1 and 3 (each within the scatter of the next).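

In this assay, pyridin-4-yl on the amine nitrogen in a ring gives a number 5 percentage points lower from compound 1 to compound 4 (within the scatter), a number 3 percentage points lower from compound 2 to compound 4 (within the scatter) and a number 7.2 percentage points lower from compound 3 to compound 4 (within the scatter). Within the data shown here, the step from the pyridin-3-yl compound is the first to change only where the hetero atom sits in the aromatic ring, and this change stays within the scatter, as does replacing either dichlorophenyl group with pyridin-4-yl. No available evidence explains this result.

The compounds shown leave open how this position would respond to a group without an aromatic ring, such as cyclohexyl, a longer alkyl chain or a carboxylic acid. They also leave open whether the four compounds, read here at one concentration only, would show a stronger or weaker effect at any other concentration.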